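The source may report more compounds than this note shows. Statements on the series, on what has been measured and on what is new or still open speak of the compounds shown alone.

In a functional assay on U-937 cells (Homo sapiens) (on this read-out lower numbers stand for stronger inhibition and higher numbers for weaker inhibition), compound 1 (`COc1cc(C(=O)NS(=O)(=O)c2ccccc2C)ccc1Cc1cn(C=O)c2ccc(NC(=O)OC3CCCC3)cc12`) gives 0.6 nM and compound 2 (`COc1cc(C(=O)NS(=O)(=O)c2ccccc2C)ccc1Cc1c[nH]c2ccc(NC(=O)OC3CCCC3)cc12`) gives 2 nM, the higher of the two numbers. Compound 3 (`COc1cc(C(=O)NS(=O)(=O)c2ccccc2C)ccc1Cc1cn(C(=O)NCCN(C)C)c2ccc(NC(=O)OC3CCCC3)cc12`) differs from compound 2 by (2-(dimethylamino)ethyl)carbamoyl in place of hydrogen on an aromatic nitrogen. Among the compounds with values here, only one measured step touches that nitrogen, a 3.3-fold higher number from compound 1 to compound 2 (0.52 log units; beyond the scatter), a modest step on replacing formyl with hydrogen. Within the data shown here, no measured compound carries the new chain, so the reverse direction, a modest move to a lower number, is only a tentative expectation. The expected change is a 1.7-fold lower number from compound 2 to compound 3 (0.22 log units; within the scatter). For compound 3 the estimated value is 1.2 nM, with an expected range of 0.35 nM to 4.5 nM.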

Compound 3, half-maximal inhibitory concentration: 0.1 nM
Compound 3: middle estimate off by 12-fold (1.08 log units), on the high side, outside the stated range (below it).
By their numbers in this assay, from the lowest: compound 3; then compound 1; then compound 2.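

On the aromatic nitrogen, in this assay, the larger chain gives a 20-fold lower number from compound 2 to compound 3 (1.30 log units; beyond the scatter) and, set against formyl, a 6.0-fold lower number from compound 1 to compound 3 (0.78 log units; beyond the scatter). This position therefore accepts (2-(dimethylamino)ethyl)carbamoyl, and compound 3 has the lowest number of the three, with both carbonyl-bearing compounds lower than compound 2. No measurement available here explains the gain. Which part of the chain carries the step remains open. A simple methylcarbamoyl group, or a chain ending in hydroxyl instead of dimethylamino, would separate the carbamoyl from the terminal amine.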